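The source may hold more compounds than are shown below. What is called first, only, known or untested is meant among the compounds shown, and "the series" means these compounds.

Compound 1 `COc1ccc(C(=O)c2ccc3c(c2)C(n2ccccc2=O)=CC(C)(C)O3)cc1`: 5.72 in a functional assay (trachea) with Rattus norvegicus as the target; on this read-out higher numbers stand for higher potency (the scale is a negative logarithm) and lower numbers for lower potency
Compound 2 `CC1(C)C=C(n2ccccc2=O)c2cc(C(=N)NO)ccc2O1`: 5.51 in this assay

On these two numbers compound 2 stands alongside compound 1, the pair falling within the usual scatter of each other, so neither can be set above the other. Compound 3 `CC1(C)C=C(n2ccccc2=O)c2cc(C(F)(F)F)ccc2O1` differs from compound 2 by a group of 4 heavy atoms (1 carbon, 3 fluorine; no ring) in place of a group of 4 heavy atoms (1 carbon, 2 nitrogen, 1 oxygen; no ring), on an aromatic carbon. Among the compounds with values here, no measured pair shows this change, so the step of a number 0.09 log units higher from compound 2 to compound 3 (within the scatter) is expected to stay within the scatter, with no direction claimed. Compound 3 is therefore expected to give about 5.6 in this assay, between 4.9 and 6.3.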

Compound 3, logarithm of the reciprocal of the active concentration, log(1/C): 7.37
Beside the measured number, compound 3's estimate is 1.77 log units below it; the measured number lies above the stated range.
By their numbers in this assay, from the lowest: compounds 2 and 1 (each within the scatter of the next); then compound 3.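

In this assay, trifluoromethyl in place of the earlier group on this aromatic carbon gives a number 1.86 log units higher from compound 2 to compound 3 (beyond the scatter) and so shows that this position can shift potency sharply. Compound 1 and compound 2, which lie within the scatter of each other, gave no sign of a change this large. Nothing available here bears on why this replacement has such an effect.

Going by these compounds, how a nitrile, a methyl group or a chlorine atom would read on this aromatic carbon remains open. Also open, on these data alone, is whether trifluoromethyl would give a similar step on another carbon of the same ring.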